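The source may report more compounds than this note shows. Statements on the series, on what has been measured and on what is new or still open speak of the compounds shown alone.

Among the compounds with values here, compound 2 `O=C(/C=C/c1c[nH]c2ccccc12)Nc1ccc2ncnc(Nc3cccc(Cl)c3)c2c1` holds the lowest of the two numbers so far: in a functional assay on A549 cells (Homo sapiens) for antiproliferative activity, read by MTT assay, with a stated time of 48 h (on this read-out lower numbers stand for stronger inhibition and higher numbers for weaker inhibition), compound 2 gives 3670 nM. Within the data shown here, its nearest neighbour, compound 1 `O=C(/C=C/c1cccs1)Nc1ccc2ncnc(Nc3cccc(Cl)c3)c2c1`, in this assay gives 9310 nM, and the single step between them, a 2.5-fold lower number from compound 1 to compound 2 (0.40 log units; beyond the scatter), is the only information on how the aryl group on the double-bonded chain carbon moves the number.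

Compound 3 `Cc1cccc(/C=C/C(=O)Nc2ccc3ncnc(Nc4cccc(Cl)c4)c3c2)n1` has not yet been measured in this assay. It differs from compound 2 by 6-methylpyridin-2-yl in place of 1H-indol-3-yl on a double-bonded chain carbon bound to a double-bonded chain carbon. Among the measured compounds shown here, no measured step exchanges an indolyl for a pyridyl group, so the step from compound 1 to compound 2 bears on it only in showing that swapping the aryl group at this place shifts the number modestly. Because compound 1 with its thiophen-2-yl gives 9310 nM while the indolyl analogue sits lower, compound 3 is expected to land between those two values, a step of a 1.9-fold higher number from compound 2 to compound 3 (0.28 log units; within the scatter) toward a higher number. Compound 3 is therefore estimated at 7000 nM, with a range from 2800 nM to 18000 nM.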

Compound 3, half-maximal inhibitory concentration: 2160 nM
For compound 3 the middle estimate is 3.2-fold (0.51 log units) above the measured one; the whole stated range lies above it.
By their numbers in this assay, from the lowest: compounds 3 and 2 (each within the scatter of the next); then compound 1.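

In this assay, a 1.7-fold lower number from compound 2 to compound 3 (0.23 log units; within the scatter) leaves the 6-methylpyridin-2-yl and 1H-indol-3-yl groups indistinguishable at this place on the double-bonded chain carbon, even though the entering group has 7 heavy atoms against 9, a single six-membered aromatic ring with 1 hetero atom, and 0 hydrogen-bond donors against 1, so the second ring and the hydrogen-bond donor of the 1H-indol-3-yl group are not needed to hold the number at this level. With a 4.3-fold lower number from compound 1 to compound 3 (0.63 log units; beyond the scatter), a second aryl group now stands beyond the scatter from thiophen-2-yl, so the lower reading no longer rests on the 1H-indol-3-yl group alone, and the three compounds fall into two levels, with compound 1 on its own at the higher one. No measurement shown here accounts for these shifts.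

From the compounds shown here alone, what the methyl group itself contributes remains open, and an unsubstituted pyridin-2-yl group would separate it from the ring nitrogen. Going by these compounds, all three groups at this place are aromatic, so it is also open how a cyclohexyl group or a dimethylaminomethyl-bearing aryl group would read in this assay.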